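Carbamate in place of urea on a shared core

The compounds below may be only part of what the source reports. "The series", "measured", "known", "first", "only" and "open" are said of these compounds alone.

Compound 1 `COc1ccc(S(=O)(=O)N2CCc3cccc(NC(=O)c4ccc([N+](=O)[O-])cc4)c32)cc1` carries a 4-nitrophenyl on the carbonyl carbon of its amide. In a functional assay on MKN-45 cells (Homo sapiens) for cytotoxicity (on this read-out lower numbers stand for stronger inhibition and higher numbers for weaker inhibition), compound 1 gives 95 nM. Compound 2 `COc1ccc(S(=O)(=O)N2CCc3cccc(NC(=O)N(C)c4ccccc4)c32)cc1` has methyl(phenyl)amino in place of 4-nitrophenyl on that carbonyl carbon. In this assay compound 2 reaches only a limit of the assay, > 10000 nM, so no exact number exists for it. The recorded step is an at least 100-fold higher number from compound 1 to compound 2 (2.02 log units; beyond the scatter), and compound 2 therefore sits at the weak end of what has been measured, as shown by the limit of > 10000 nM in this assay, at which 1 of the 2 values shown sits.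

Compound 3 `COc1ccc(S(=O)(=O)N2CCc3cccc(NC(=O)Oc4ccccc4)c32)cc1` is not yet measured. It differs from compound 2 in one place: phenoxy in place of methyl(phenyl)amino on a carbonyl carbon. Among the compounds with values here, the single measured step covers an aryl amide turning into a urea, not a urea turning into a carbamate, so no measured step bears directly on this change. That one step was large and toward weaker inhibition, which leaves the outlook for compound 3 uncertain and tilted toward weak inhibition. Compound 3 is expected at about 6000 nM, within 1000 nM to 30000 nM, in this assay. The step this estimate means is an at least 1.6-fold lower number from compound 2 to compound 3 (0.22 log units; that floor lies within the scatter).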

Compound 3, half-maximal inhibitory concentration: > 10000 nM
Compound 3: a limit, no number; the forecaster's own chance of this, stated with the estimate: 50%; middle value at least 1.6-fold (0.22 log units) away from the limit.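

The phenoxy carbamate behaves like the urea, not like the aryl amide: an at least 100-fold higher number from compound 1 to compound 3 (2.02 log units; beyond the scatter). A second group in place of 4-nitrophenyl on this carbonyl carbon thus gives a weak result in this assay, so the loss seen with compound 2 does not depend on the methyl(phenyl)amino group alone. The step from compound 2 to compound 3 cannot be read, so the data do not rank phenoxy against methyl(phenyl)amino, and compound 1 remains the only compound here with an exact number, the other two sitting at one limit of the assay: the limit of > 10000 nM in this assay, at which 2 of the 3 values shown sit.

Compounds 2 and 3 both lose the nitro group and both attach their phenyl ring to the carbonyl carbon through a further atom, a nitrogen in one and an oxygen in the other, so the two changes cannot be told apart. Still open, on these data alone, is how an amide would fare with its ring bonded directly to the carbonyl carbon and with a plain phenyl, or with an amine or a carboxylic acid in place of the nitro group.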